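This account rests on a few compounds, and the source may have more. Where it says the series, first, only, none or still open, it means among the compounds named here.

Measured compounds in an assay on CHO cells for displacement of a labelled ligand from adenosine receptor A3 (Homo sapiens), read by scintillation counting, with a stated time of 3 h; a lower number here means a stronger inhibitor, a higher number a weaker inhibitor:
- compound 1 `CCn1c(-c2ccccc2)nc2c(NC3CCCCC3)ncnc21` gives 707 nM
- compound 2 `Cn1c(-c2ccccc2)nc2c(NC3CCCCC3)ncnc21` gives 2370 nM
- compound 3 `CCCn1c(-c2ccccc2)nc2c(NC3CCCCC3)ncnc21` gives 2360 nM

Compound 1 stands lowest of the measured numbers in this assay. The steps away from it are a 3.4-fold higher number from compound 1 to compound 2 (0.53 log units; beyond the scatter) and a 3.3-fold higher number from compound 1 to compound 3 (0.52 log units; beyond the scatter), both beyond the scatter; between compound 2 and compound 3 the step is a 1.0-fold lower number from compound 2 to compound 3 (0.00 log units; within the scatter), within the scatter. All of these concern the saturated chain on the aromatic nitrogen and leave the cyclohexylamino part untouched.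

Compound 4 `CCn1c(-c2ccccc2)nc2c(N)ncnc21` differs from compound 1 in a different place: hydrogen in place of cyclohexyl on a nitrogen on an aromatic ring. Going by the values given here, none of the measured steps touches this part of the shared core, so the measured series gives no direct guide to the size of this step. Among the compounds with values here, the chain steps show only that changes of one or two chain carbons move the number by modest amounts in this assay. For the removal of the whole cyclohexyl from the ring nitrogen, the expectation is a step from compound 1 to compound 4 of a 14-fold higher number from compound 1 to compound 4 (1.15 log units; beyond the scatter), towards a higher number. Compound 4 is therefore estimated at 10000 nM, within a range of 2000 nM to 50000 nM.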

Compound 4, inhibition constant: 5780 nM
Estimate against measurement, compound 4: 1.7-fold (0.24 log units) above; the range from low to high includes it.
By their numbers in this assay, from the lowest: compound 1; then compounds 3 and 2 (each within the scatter of the next); then compound 4.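

In this assay the change from cyclohexylamino to amino, with the ethyl chain on the aromatic nitrogen held constant, gives an 8.2-fold higher number from compound 1 to compound 4 (0.91 log units; beyond the scatter). Going by these compounds alone, this is the first measured step at this nitrogen on the aromatic ring, and it shows that the cyclohexyl contributes to the lower number of compound 1 but is not needed for a measurable number, since compound 4 still gives a value and not a limit of the assay. No measurement shown here offers an explanation for the size of this step.

Open, from the compounds shown here alone, is where cyclopentyl, benzyl or a short methyl chain on this nitrogen would fall relative to compound 1 and compound 4. Also open, going by these compounds, is whether the chain steps on the aromatic nitrogen would hold with amino in place of cyclohexylamino.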